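A Pyridine for a Phenyl on a Second Core

The source may hold more compounds than are shown below. What is called first, only, known or untested is meant among the compounds shown, and "the series" means these compounds.

Four compounds are compared here, all of them phosphate diesters that carry an aromatic group on one oxygen. Compound 1 `Cc1cn([C@H]2C[C@H](N=[N+]=[N-])[C@@H](COP(=O)(O)Oc3cccnc3)O2)c(=O)[nH]c1=O` and compound 2 `Cc1cn([C@H]2C[C@H](N=[N+]=[N-])[C@@H](COP(=O)(O)Oc3ccccc3)O2)c(=O)[nH]c1=O` share one core, while compound 3 `Nc1ncnc2c1ncn2[C@H]1CC[C@@H](COP(=O)(O)Oc2ccccc2)O1` is built on a different core; the difference between the two cores is not broken down here. Compound 4 `Nc1ncnc2c1ncn2[C@H]1CC[C@@H](COP(=O)(O)Oc2cccnc2)O1` is built on the core of compound 3 and has not yet been measured.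

In a physicochemical assay for metabolic stability, read by HPLC (on this read-out lower numbers stand for a shorter-lived compound and higher numbers for a longer-lived compound), compound 1 gives 3.88 h. In this assay compound 2 gives 9.47 h. Compound 3 gives 36.1 h in this assay, the highest of the three numbers.

Between compound 2 and compound 1 the only change is pyridin-3-yl in place of phenyl on an oxygen, and its effect in this assay is a 2.4-fold lower number from compound 2 to compound 1 (0.39 log units; beyond the scatter). Compound 4 is related to compound 3 by pyridin-3-yl in place of phenyl on an oxygen, at the same place, so the same change occurs twice among these compounds, once measured and once not.

For compound 4 in this assay a step of a 2.4-fold lower number from compound 3 to compound 4 (0.38 log units; beyond the scatter) is expected. Among the compounds with values here, this expectation rests on the single measured example, a 2.4-fold lower number from compound 2 to compound 1 (0.39 log units; beyond the scatter), carried over to a different core with no second precedent. Compound 4 is therefore estimated at 15 h in this assay. The range for compound 4 is estimated to run from 7 h to 32 h, wider than the earlier step alone would suggest.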

Compound 4, half-life: 64.2 h
Compound 4: the middle estimate sits 4.3-fold (0.63 log units) below what was measured; measured number outside the range, above it.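

On the core of compound 3, putting pyridin-3-yl in place of phenyl on an oxygen gives a 1.8-fold higher number from compound 3 to compound 4 (0.25 log units; within the scatter) in this assay and so leaves compound 3 and compound 4 indistinguishable, whereas on the core of compound 1 the same change gave a 2.4-fold lower number from compound 2 to compound 1 (0.39 log units; beyond the scatter) in a step that stood clear of the usual scatter. This shows that the drop seen on one core did not reappear on the other, so in these two pairs a single step was a poor guide across cores, but it does not show that pyridin-3-yl lengthens the half-life on the second core, and two pairs cannot set a rule for the whole series. Nothing available here explains why the two cores behave differently.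

The compounds shown leave open whether a third core would follow either pair, or neither. They also leave open how either core would respond if the group on the oxygen were a phenyl carrying an amine or a carboxylic acid, rather than phenyl or pyridin-3-yl.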